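The compounds below may be only part of what the source reports. "The series", "measured", "known", "first", "only" and "open" are said of these compounds alone.

Compound 1 `CCCOc1ccc(C(=O)Nc2cccc(Cl)n2)cc1` gives > 100000 nM in an in vitro assay on HEK-tsA201 cells for antagonist activity at Neuronal acetylcholine receptor; alpha4/beta2 (Homo sapiens), read by fluorescence and calcium flux (on this read-out lower numbers stand for stronger inhibition and higher numbers for weaker inhibition), which is a limit of the assay and not a number.
Compound 2 `CCCCNc1cccc(NC(=O)c2ccc(OCCC)cc2)n1` gives 54100 nM in this assay.

Compound 2 thus holds the only number shown and is a weak inhibitor in this assay. Compound 1 sits at the limit (the limit of > 100000 nM in this assay, at which 1 of the 2 values shown sits). Compound 3 `CCCCCNc1cccc(NC(=O)c2ccc(OCCC)cc2)n1` differs from compound 2 by methyl in place of hydrogen on a saturated chain carbon, four bonds along the chain from a nitrogen on an aromatic ring. Going by the values given here, the one measured step, an at least 1.8-fold lower number from compound 1 to compound 2 (0.26 log units; that floor lies within the scatter), alters a different part of the molecule, so no measured step bears on this lengthening of the chain. No change beyond the scatter is therefore expected in this assay, and the expected step is a 1.1-fold lower number from compound 2 to compound 3 (0.03 log units; within the scatter). Compound 3 is estimated at 50000 nM, within 18000 nM to 140000 nM.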

Compound 3, half-maximal inhibitory concentration: > 100000 nM
Compound 3: a limit, no number; the forecaster's own chance of this, stated with the estimate: 30%; middle value at least 2.0-fold (0.30 log units) away from the limit.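

Adding one methyl to the end of the butylamino chain gives an at least 1.8-fold higher number from compound 2 to compound 3 (0.26 log units; that floor lies within the scatter) in this assay, so this end of the chain shows no gain in inhibition from the longer pentylamino group. That step rests on a limit of the assay, not on a number, and the step from compound 1 to compound 3 cannot be read. Compound 3 joins compound 1 at the limit: the limit of > 100000 nM in this assay, at which 2 of the 3 values shown sit.

Still open, on these data alone, is whether a shorter propylamino chain, or a butyl chain ending in an amine or a carboxylic acid, would inhibit more strongly than compound 2.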